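Bis-amide series: nitrile in place of dichlorophenyl

The source may report more compounds than this note shows. Statements on the series, on what has been measured and on what is new or still open speak of the compounds shown alone.

Measured compounds:
compound 1 `COc1ccccc1C(=O)Nc1cccc(NC(=O)c2ccc(Cl)cc2)c1` — > 30000 nM
compound 2 `COc1ccccc1C(=O)Nc1cccc(NC(=O)c2cc(Cl)cc(Cl)c2)c1` — > 30000 nM

In an in vitro functional assay on HEK293-A cells for antagonist activity at metabotropic glutamate receptor 5 (Rattus norvegicus), read by calcium flux (a lower number here means a stronger inhibitor, a higher number a weaker inhibitor), compound 1 gives only a limit, > 30000 nM. Compound 2 likewise gives only a limit in this assay, namely > 30000 nM. The step that the two limits leave unreadable from compound 1 to compound 2 is therefore unreadable in size and direction. Within the data shown here, both values sit at the limit of > 30000 nM in this assay, at which 2 of the 2 values shown sit, so compound 2 stands at that limit and nowhere else on the numbers so far; no finite potency is known for it.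

Compound 3 `COc1ccccc1C(=O)Nc1cccc(NC(=O)c2cccc(C#N)c2)c1` is the next member. It differs from compound 2 in one place: 3-cyanophenyl in place of 3,5-dichlorophenyl on a carbonyl carbon. Among the measured compounds shown here, the single measured step, from compound 1 to compound 2, also exchanged the ring on that carbonyl carbon and left no readable size, so no measured step supplies a direction for the move to the nitrile. What is expected rests only on compound 2 standing at the limit of > 30000 nM in this assay, at which 2 of the 2 values shown sit. The step expected in this assay is a step that the limit leaves unreadable from compound 2 to compound 3, which is no readable change beyond the scatter. Compound 3 is estimated at 40000 nM, in the range 8000 nM to 150000 nM, and is expected most probably to be reported again only as a limit.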

Compound 3, half-maximal inhibitory concentration: 1800 nM
The estimate for compound 3 lay 22-fold (1.35 log units) above the measured number; measured number outside the range, below it.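

In this assay the ring on this carbonyl carbon is now seen to set whether the series gives a finite potency at all, with compound 3 reading 1800 nM. Exchanging 3,5-dichlorophenyl for 3-cyanophenyl gives an at least 16-fold lower number from compound 2 to compound 3 (1.22 log units; beyond the scatter), and exchanging 4-chlorophenyl for 3-cyanophenyl gives an at least 16-fold lower number from compound 1 to compound 3 (1.22 log units; beyond the scatter); both figures are bounds on the size of the change, not measured sizes. The two chlorinated rings alone could not show that this place responds to what it carries with the rest of the shared core held constant, since compound 1 and compound 2 both rest on one limit of the assay: the limit of > 30000 nM in this assay, at which 2 of the 3 values shown sit.

As far as these compounds go, whether the gain belongs to the nitrile itself or to the loss of chlorine from the ring stays open, as does the true size of both steps, and the step between the two chlorinated compounds cannot be read. Also open, from the compounds shown here alone, is how far this place tolerates other groups, such as a carboxylic acid, a primary amide or an aminomethyl group, in place of the nitrile on this ring.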